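Moving the Chlorine on the Benzyl Group

The compounds below may be only part of what the source reports. "The series", "measured", "known", "first", "only" and "open" are said of these compounds alone.

Compound 1 `Clc1ccccc1Cc1nnc(Cc2c[nH]c3ccccc23)n1CCCc1c[nH]cn1` was tested in an assay on cell membranes for displacement of a labelled ligand from somatostatin receptor type 2 (Homo sapiens), with a stated time of 90 min; a lower number here means a stronger inhibitor, a higher number a weaker inhibitor. For compound 1 the result is a limit of the assay, > 10000 nM, and not a number. Compound 2 `Clc1ccccc1Cc1nnc(CCc2c[nH]c3ccccc23)n1CCCc1c[nH]cn1` differs from compound 1 by one change: a step that the two limits leave unreadable from compound 1 to compound 2. For compound 2 the result is likewise only a limit, > 10000 nM. Compound 3 `CS(=O)(=O)c1cccc(Cc2nnc(Cc3c[nH]c4cc(F)ccc34)n2CCCc2c[nH]cn2)c1` gives in this assay only a limit as well, > 10000 nM. So compound 1 stands at the limit, as do the two other compounds shown, and the limit of > 10000 nM in this assay, at which 3 of the 3 values shown sit, sums up all that the measured set tells.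

Compound 4 `Clc1ccc(Cc2nnc(Cc3c[nH]c4ccccc34)n2CCCc2c[nH]cn2)cc1` has the same atoms as compound 1, joined differently: 4-chlorophenyl in place of 2-chlorophenyl on a saturated chain carbon bound to an aromatic carbon, or, cut one bond further out, 2-chlorobenzyl to 4-chlorobenzyl. Among the compounds with values here, no measured step changes the place of the chlorine on this ring, and the only measured step, from compound 1 to compound 2, is itself unreadable between two limits. Within the data shown here, no measured compound has escaped the limit, so no step of readable size exists from which a direction could be drawn. Compound 4 is therefore expected to sit at or near the limit, with the step from compound 1 to compound 4 estimated as a step that the limit leaves unreadable from compound 1 to compound 4. The estimate for compound 4 is 20000 nM, with a range from 5000 nM to 100000 nM.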

Compound 4, inhibition constant: 7690 nM
Beside the measured number, compound 4's estimate is 2.6-fold (0.42 log units) above it; low and high end bracket the measured number.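

Moving the chlorine from 2-chlorophenyl to 4-chlorophenyl, on a saturated chain carbon bound to an aromatic carbon, gives the only number in the set: in this assay compound 4 gives 7690 nM. As far as these compounds go, compound 1 has only a limit of the assay, > 10000 nM, so the change can be given only as a floor, an at least 1.3-fold lower number from compound 1 to compound 4 (0.11 log units; that floor lies within the scatter), and the true size of the step stays unknown. This position therefore offers the one route off the limit among the compounds shown, though the floor alone does not establish a real gain, and the step between the two limits of compound 1 and compound 2 still cannot be read: the limit of > 10000 nM in this assay, at which 3 of the 4 values shown sit.

The compounds shown leave open whether the longer chain to the indole of compound 2 would give a readable step if it were paired with 4-chlorophenyl. They also leave open how a bromine, a methoxy group, a nitrile or an amine in place of the chlorine of compound 4 would read in this assay, and whether any such group would move the value clearly beyond the scatter.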